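Swapping the Ring on the Amide Nitrogen

The compounds below may be only part of what the source reports. "The series", "measured", "known", "first", "only" and "open" are said of these compounds alone.

- compound 1 `CCc1nn(C2CCCC2)c2c1CCN(c1ccccc1)C2=O`: 70 nM
- compound 2 `CCc1nn(C2CCCC2)c2c1CCN(c1ccsc1)C2=O`: 36 nM

Among the measured compounds shown here, in a functional assay on U-937 cells (Homo sapiens), read by cAMP accumulation (a higher number here means that more compound is needed for the effect, a lower number that less compound is needed), compound 2 lies within the scatter of compound 1, as the only measured step shows: a 1.9-fold lower number from compound 1 to compound 2 (0.29 log units; within the scatter). Compound 3 `CCc1nn(C2CCCC2)c2c1CCN(c1cccc(Cl)c1)C2=O` brings a new change, (3-chlorophenyl in place of thiophen-3-yl on an amide-type nitrogen in a ring), placing 3-chlorophenyl in place of thiophen-3-yl on an amide-type nitrogen in a ring. For the measured compounds named here, no measured compound carries the chlorine, so that one small step is the only guide, and no shift beyond the scatter is expected in this assay. The expected change is a 1.3-fold higher number from compound 2 to compound 3 (0.10 log units; within the scatter). For compound 3 the estimate is 45 nM, with an expected range of 15 nM to 130 nM.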

Compound 3, half-maximal effective concentration: 41 nM
Compound 3: the middle estimate sits 1.1-fold (0.04 log units) above what was measured, and the stated range covers the measured number.
By their numbers in this assay, from the lowest: compounds 2, 3 and 1 (each within the scatter of the next).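

The numbers in this assay stay close: 3-chlorophenyl in place of thiophen-3-yl gives (a 1.1-fold higher number from compound 2 to compound 3 (0.06 log units; within the scatter)), and chloro in place of hydrogen on an aromatic carbon gives (a 1.7-fold lower number from compound 1 to compound 3 (0.23 log units; within the scatter)). The amide-type nitrogen has thus carried phenyl, thiophen-3-yl and 3-chlorophenyl, with every step within the scatter, so adding chloro shifts nothing measurable here. Nothing available explains why these numbers stay together.

Still open, on these data alone, is what this position does with a group that is not an aromatic ring, such as a longer alkyl chain, or with a phenyl carrying an amine or a carboxylic acid.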